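From trichloromethyl to vinyl at the assay limit

A few compounds are considered here, and "the series" means these few. Any claim that something is new, unique, unknown or untested is made for them only; others in the source may bear on it.

Compound 1 (`CCOC(=O)c1ccsc1NC(=O)[C@@H]1CCCN1`) gives (> 250 ug/mL)
Compound 2 (`O=C(Oc1ccccc1)c1ccsc1NC(=O)[C@@H]1CCCN1`) gives (> 250 ug/mL)
Compound 3 (`O=C(OCC(Cl)(Cl)Cl)c1ccsc1NC(=O)[C@@H]1CCCN1`) gives (> 250 ug/mL)

In a functional assay on MCF7 cells (Homo sapiens) for inhibition (a higher number here means a weaker inhibitor of growth, a lower number a stronger inhibitor of growth), compound 3 stands only at a limit (> 250 ug/mL), not at a number. The whole series rests on one reading (the limit of > 250 ug/mL in this assay, at which 3 of the 3 values shown sit).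

Compound 4 (`C=CCOC(=O)c1ccsc1NC(=O)[C@@H]1CCCN1`) follows from compound 3 by one change (vinyl in place of trichloromethyl on a saturated chain carbon bound to an oxygen next to a carbonyl group), which puts vinyl in place of trichloromethyl on a saturated chain carbon bound to an oxygen next to a carbonyl group.

Going by the values given here, three measured steps bear on this place: (a step that the two limits leave unreadable from compound 1 to compound 2), (a step that the two limits leave unreadable from compound 1 to compound 3) and (a step that the two limits leave unreadable from compound 2 to compound 3). None of them has a readable size, and none gives a direction. So the data offer no ground for expecting anything beyond the scatter in this assay, up or down.

The expected step is small and without a firm direction (a step that the limit leaves unreadable from compound 3 to compound 4).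

For compound 4 the estimate is (300 ug/mL), with an expected range from (180 ug/mL) to (500 ug/mL), and a further limit is the likeliest report.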

Compound 4, concentration for 50% growth inhibition: 96.6 ug/mL
The estimate for compound 4 lay 3.1-fold (0.49 log units) above the measured number; the measured number lies below the stated range.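

In this assay, the earlier compounds said nothing about this place, since ethyl, phenyl and 2,2,2-trichloroethyl on an oxygen next to a carbonyl group all gave the same limit, and the steps among them cannot be read: the limit of > 250 ug/mL in this assay, at which 3 of the 4 values shown sit.

Allyl is the first group here to give a number, so this place can respond to a change, with an at least 2.5-fold lower number from compound 3 to compound 4 (0.41 log units; beyond the scatter), an at least 2.5-fold lower number from compound 2 to compound 4 (0.41 log units; beyond the scatter) and an at least 2.5-fold lower number from compound 1 to compound 4 (0.41 log units; beyond the scatter). Each of these sizes is only a minimum, as each starts from a limit.

The compounds shown leave open whether the double bond of allyl matters or the chain alone does, a question that propyl or a longer chain such as butyl would bear on. They also leave open what an amine or a carboxylic acid at the end of that chain would do.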